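A few compounds are considered here, and "the series" means these few. Any claim that something is new, unique, unknown or untested is made for them only; others in the source may bear on it.

In a functional assay on PANC-1 cells (Homo sapiens) for inhibition, read by MTT assay, with a stated time of 24 h, tested at 10 uM (a lower number here means less inhibition, a higher number more inhibition at the concentration tested (going by the name of the read-out)), three compounds sharing one core have been measured: compound 1 `CC(C)=CCC1Cc2c(OC(=O)Nc3ccc(F)c(Cl)c3)cc(=O)n(CCCO)c2CC1(C)C` gives 0%, compound 2 `CC(C)=CCC/C(C)=C/CC1Cc2c(OCCCOc3ccc(Cl)cc3)cc(=O)n(CCCO)c2CC1(C)C` gives 0%, and compound 3 `COc1cccc(NC(=O)Oc2cc(=O)n(CCCO)c3c2CC(C/C=C(\C)CCC=C(C)C)C(C)(C)C3)c1` gives 11.3%, which is the highest of the three numbers. Within the data shown here, the only single-place step measured is a number 11.3 percentage points higher from compound 2 to compound 3 (beyond the scatter). Compound 4 `CC(C)=CCC/C(C)=C/CC1Cc2c(OC(=O)Nc3ccc(F)c(Cl)c3)cc(=O)n(CCCO)c2CC1(C)C` has not yet been measured. It differs from compound 3 by 3-chloro-4-fluorophenyl in place of 3-methoxyphenyl on an amide-type nitrogen. Among the measured compounds shown here, no measured step tests this change directly; the nearest guide is compound 1, which carries the same 3-chloro-4-fluorophenyl on an amide-type nitrogen and gives 0%. Compound 4 is therefore expected to fall back toward that level, a step of a number 7.3 percentage points lower from compound 3 to compound 4 (within the scatter). Compound 4 is estimated at 4%, with a range from 0% to 14%.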

Compound 4, a percentage reported as inhibition, at one concentration (the size of the read-out at that concentration, not a potency): 0%
Estimate against measurement, compound 4: 4 percentage points above; low and high end bracket the measured number.
By their numbers in this assay, from the lowest: compounds 1, 2 and 4 (each within the scatter of the next); then compound 3.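

In this assay, the group on the amide-type nitrogen now has a direct test: a number 11.3 percentage points lower from compound 3 to compound 4 (beyond the scatter), so 3-chloro-4-fluorophenyl does not retain the reading seen with 3-methoxyphenyl. With 3-chloro-4-fluorophenyl in that place, the longer chain on the shared core gives no change at the digits printed from compound 1 to compound 4 (within the scatter). Replacing 3-(4-chlorophenoxy)propyl on the oxygen gives no change at the digits printed from compound 2 to compound 4 (within the scatter), so the carbamoyl link alone does not separate these compounds.

Nothing measured here accounts for these results. On these data alone, whether a phenyl ring carrying a dimethylamino group or a carboxylic acid on the amide-type nitrogen would change the reading remains open.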